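The source may hold more compounds than are shown below. What is called first, only, known or untested is meant among the compounds shown, and "the series" means these compounds.

Compound 3 `Nc1ccccc1NC(=O)c1ccc(CSC(=S)N2CCN(Cc3ccccc3)CC2)cc1` gives 10.6% in a functional assay on A-375 cells (Homo sapiens) for antiproliferative activity, read by CCK-8 assay, with a stated time of 72 h, tested at 2 uM (a higher number here means a stronger effect of the compound at the concentration tested, a lower number a weaker effect), the lowest of the three measured values. Compound 1 `COc1ccc(N2CCN(C(=S)SCc3ccc(C(=O)Nc4ccccc4N)cc3)CC2)cc1` gives 28.1%, and compound 2 `Nc1ccccc1NC(=O)c1ccc(CSC(=S)N2CCN(c3ccncc3)CC2)cc1` gives 85.7%. Compound 4 `Nc1ccccc1NC(=O)c1ccc(CSC(=S)N2CCN(c3ccccc3F)CC2)cc1` differs from compound 3 by 2-fluorophenyl in place of benzyl on an amine nitrogen in a ring. Among the measured compounds shown here, the steps that bear on this change are those at the same place: a number 17.5 percentage points lower from compound 1 to compound 3 (beyond the scatter) and a number 75.1 percentage points lower from compound 2 to compound 3 (beyond the scatter), so replacing the benzyl by 4-methoxyphenyl or pyridin-4-yl raised the read-out by modest to large amounts, while a number 57.6 percentage points higher from compound 1 to compound 2 (beyond the scatter) shows how widely such groups can differ. A rise beyond the scatter is therefore expected, of size a number 29.4 percentage points higher from compound 3 to compound 4 (beyond the scatter). Compound 4 is estimated at 40%, with a range from 15% to 75%.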

Compound 4, a percentage reported as inhibition, at one concentration (the size of the read-out at that concentration, not a potency): 18.7%
Beside the measured number, compound 4's estimate is 21.3 percentage points above it; the measured number falls inside the stated range.
By their numbers in this assay, from the lowest: compounds 3, 4 and 1 (each within the scatter of the next, the first and the last beyond it); then compound 2.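

Placing 2-fluorophenyl on the amine nitrogen gives a number 8.1 percentage points higher from compound 3 to compound 4 (within the scatter) when it replaces benzyl and a number 9.4 percentage points lower from compound 1 to compound 4 (within the scatter) when it replaces 4-methoxyphenyl, so these three groups cannot be told apart here. Replacing pyridin-4-yl with it gives a number 67 percentage points lower from compound 2 to compound 4 (beyond the scatter), which leaves compound 2 alone in standing apart from the other three compounds. Nothing measured on these compounds explains that gap. Still open, on these data alone, is whether the nitrogen of the pyridine ring, or where it sits, matters. A pyridin-3-yl or pyridin-2-yl group at this place would address that question.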